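A Sulfur-Bearing Chain Replaces Pentyl on the Acylguanidine Core

The source may report more compounds than this note shows. Statements on the series, on what has been measured and on what is new or still open speak of the compounds shown alone.

Three acylguanidines have been measured in a functional assay for inhibition of sodium/hydrogen exchanger (Oryctolagus cuniculus); on this read-out higher numbers stand for weaker inhibition and lower numbers for stronger inhibition. Compound 1 `Cc1c(C(=O)N=C(N)N)cc(S(C)(=O)=O)c(Cl)c1Cl` gives 29 nM. Compound 2 `Cc1c(C(=O)N=C(N)N)ccc(Cl)c1S(C)(=O)=O` gives 1300 nM. Compound 3 `CCCCCc1cc(C)c(C(=O)N=C(N)N)cc1S(C)(=O)=O` gives 27 nM, the lowest of the three numbers; its nearest neighbour is compound 1, whose number is within the usual scatter of it, while compound 2 lies far above it, beyond the scatter. No pair among these three differs in only one place, so no single step between measured compounds can be read off.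

Compound 4 `CCSc1cc(C)c(C(=O)N=C(N)N)cc1S(C)(=O)=O` differs from compound 3 in one place: ethylsulfanyl in place of pentyl on an aromatic carbon. Because compound 3 gives 27 nM with the pentyl group at this position, and the change keeps a chain at the same aromatic carbon, only a modest shift, if any, is expected. The estimated step from compound 3 to compound 4 in this assay is a 1.7-fold higher number from compound 3 to compound 4 (0.22 log units; within the scatter), expected to stay close to the scatter or slightly toward weaker inhibition. Compound 4 is therefore expected to give about 45 nM, with a likely range from 12 nM to 160 nM.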

Compound 4, half-maximal inhibitory concentration: 5.9 nM
Beside the measured number, compound 4's estimate is 7.6-fold (0.88 log units) above it; measured number below the stated range.
By their numbers in this assay, from the lowest: compound 4; then compounds 3 and 1 (each within the scatter of the next); then compound 2.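

In this assay, within the data shown here, ethylsulfanyl in place of pentyl gives a 4.6-fold lower number from compound 3 to compound 4 (0.66 log units; beyond the scatter) and so provides the first step that can be read at a single place. This aromatic carbon, ortho to a methylsulfonyl group, is therefore not indifferent to the group it carries, and the step lies beyond the scatter. The pentyl chain of 5 heavy atoms is also not required for a low number here, as ethylsulfanyl, with 3 heavy atoms including 1 sulfur, gives a lower one on the same core.

Whether the sulfur or the shorter chain accounts for the step stays open, and a propyl, ethoxy or pentylsulfanyl group on this carbon would be needed to separate the two. No measurement at hand gives a reason for the step.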